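Amide aryl change in the chlorophenyl piperidine series

The source may report more compounds than this note shows. Statements on the series, on what has been measured and on what is new or still open speak of the compounds shown alone.

Measured so far:
compound 1 `CN1CC[C@@H](c2ccc(Cl)cc2)[C@@H](CSCC(=O)Nc2ccccc2)C1` — 80 nM
compound 2 `CC(=O)OCCSC[C@@H]1CN(C)CC[C@H]1c1ccc(Cl)cc1` — 536 nM

In an assay on a subcellular fraction from brain with sodium-dependent dopamine transporter (Rattus norvegicus) as the target (a lower number here means a stronger inhibitor, a higher number a weaker inhibitor), compound 1 gives 80 nM and stands lowest of the two numbers; compound 2 gives 536 nM, a gap beyond the scatter. Compound 3 `CN1CC[C@@H](c2ccc(Cl)cc2)[C@@H](CSCC(=O)Nc2cccc3ccccc23)C1` differs from compound 1 by naphthalen-1-yl in place of phenyl on an amide-type nitrogen. For the measured compounds named here, no measured pair shows this change, so nothing here fixes its size. The step of a 1.4-fold higher number from compound 1 to compound 3 (0.14 log units; within the scatter) is expected to stay near the scatter, if anything toward a weaker inhibitor. Compound 3 is estimated at 110 nM, within a range from 30 nM to 400 nM.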

Compound 3, inhibition constant: 102 nM
Beside the measured number, compound 3's estimate is 1.1-fold (0.03 log units) above it; low and high end bracket the measured number.
By their numbers in this assay, from the lowest: compounds 1 and 3 (each within the scatter of the next); then compound 2.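

On the amide-type nitrogen, naphthalen-1-yl in place of phenyl gives a 1.3-fold higher number from compound 1 to compound 3 (0.11 log units; within the scatter) in this assay, so the two compounds cannot be told apart. For the compounds shown here, at this position, then, the step from one six-membered aromatic ring to two leaves the read-out within the scatter, which no earlier pair could show. No supporting evidence bears on this result.

Open, going by these compounds, is whether a non-aromatic group on this nitrogen, such as methyl or cyclohexyl, would fit the same reading. Also open, on these data alone, is how a phenyl carrying a carboxylic acid or an amine would compare with compound 1.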